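Enaminone series on colon carcinoma cells: third analogue

The compounds below may be only part of what the source reports. "The series", "measured", "known", "first", "only" and "open" are said of these compounds alone.

Measured so far:
compound 1, `COc1ccc(N/C=C\C(=O)c2cn(-c3ccccc3)nc2-c2ccc(OC)cc2)cc1`, 8760 nM
compound 2, `COc1cc(-c2nn(-c3ccccc3)cc2C(=O)/C=C\Nc2ccc(F)cc2)cc(OC)c1OC`, 12500 nM

In a functional assay on HT-29 cells (Homo sapiens) for antiproliferative activity, read by MTT assay, with a stated time of 48 h (a lower number here means a stronger inhibitor, a higher number a weaker inhibitor), compound 1 gives 8760 nM. In this assay compound 2 gives 12500 nM, the higher of the two numbers, but its gap to compound 1 lies within the scatter, so the two compounds cannot be ordered on these data. Both sit in the weak range.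

Compound 3, `COc1cc(N/C=C\C(=O)c2cn(-c3ccccc3)nc2-c2cc(OC)c(OC)c(OC)c2)cc(OC)c1OC`, is not yet measured. It differs from compound 2 by 3,4,5-trimethoxyphenyl in place of 4-fluorophenyl on an amine nitrogen. Within the data shown here, no pair of measured compounds differs by this change alone, so there is no measured step to lean on; the shared core and the other substituents are those of compound 2. The expected step in this assay from compound 2 to compound 3 is a 1.3-fold lower number from compound 2 to compound 3 (0.10 log units; within the scatter), a change not clearly beyond the scatter in either direction. Compound 3 is therefore estimated at 10000 nM, with a range from 3000 nM to 35000 nM.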

Compound 3, half-maximal inhibitory concentration: 8400 nM
Estimate against measurement, compound 3: 1.2-fold (0.08 log units) above; measured number inside the range.
By their numbers in this assay, from the lowest: compounds 3, 1 and 2 (each within the scatter of the next).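

The amine nitrogen now has its first measured step: in this assay, 3,4,5-trimethoxyphenyl in place of 4-fluorophenyl gives a 1.5-fold lower number from compound 2 to compound 3 (0.17 log units; within the scatter), so this change cannot be distinguished from no change on these data. With the rest of compound 2 held constant, this position accepts an aromatic ring carrying three methoxy groups and hydrogen-bond acceptors that 4-fluorophenyl lacks, without a step beyond the scatter. No supporting measurement bears on this result, and it is left without an explanation.

Among these compounds, two aromatic groups give only one comparison at this nitrogen, so the range of the position remains undefined. Still open, from the compounds shown here alone, is whether a different kind of group there, such as a longer alkyl chain or a phenyl ring bearing a carboxylic acid, would give a step beyond the scatter.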